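Carbamate to thiophenesulfonamide on the core amine

The compounds below may be only part of what the source reports. "The series", "measured", "known", "first", "only" and "open" are said of these compounds alone.

Measured so far:
- compound 1 `COC(=O)NC1CCc2ccc(NC(=O)c3cccc(C)c3-c3ccc(C(F)(F)F)cc3)cc2CC1` gives 1.6 nM in an assay for inhibition of apolipoprotein B-100 (Homo sapiens), tested at 100 nM; on this read-out lower numbers stand for stronger inhibition and higher numbers for weaker inhibition
- compound 2 `COC(=O)NC1CCc2ccc(NC(=O)c3cc(C)cc(C)c3-c3ccc(C(F)(F)F)cc3)cc2CC1` gives 2.4 nM in this assay

Compound 1 holds the lowest of the two numbers. Among the compounds with values here, the only measured step, a 1.5-fold higher number from compound 1 to compound 2 (0.18 log units; within the scatter), concerns a methyl on an aromatic carbon and stays within the scatter. Compound 3 `Cc1cccc(C(=O)Nc2ccc3c(c2)CCC(NS(=O)(=O)c2cccs2)CC3)c1-c1ccc(C(F)(F)F)cc1` differs from compound 1 by (thiophen-2-yl)sulfonyl in place of methoxycarbonyl on an amine nitrogen. Within the data shown here, no measured step touches this amine nitrogen, so the measured steps give no guide; the change is large in what it counts, and a modest loss beyond the scatter is expected. Compound 3 is therefore expected near 5 nM, within 1.5 nM to 20 nM. That expectation amounts to a 3.1-fold higher number from compound 1 to compound 3 (0.49 log units; beyond the scatter).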

Compound 3, half-maximal inhibitory concentration: 1.6 nM
Compound 3: middle estimate off by 3.1-fold (0.49 log units), on the high side; the measured number falls inside the stated range.
By their numbers in this assay, from the lowest: compounds 1, 3 and 2 (each within the scatter of the next).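

On the amine nitrogen, (thiophen-2-yl)sulfonyl in place of methoxycarbonyl gives no change at the digits printed from compound 1 to compound 3 (within the scatter) in this assay. This position therefore takes a larger group, carrying a sulfonyl link and a five-membered aromatic ring, with no loss beyond the scatter, so on this pair the methoxycarbonyl is not required for a low number. Nothing available explains why the two groups read alike. Open, going by these compounds, is whether a methanesulfonyl, a benzenesulfonyl or an acetyl on this nitrogen reads the same, and how the free amine reads.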